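From 3-methoxyphenyl to benzyl on the amine nitrogen

A few compounds are considered here, and "the series" means these few. Any claim that something is new, unique, unknown or untested is made for them only; others in the source may bear on it.

In a functional assay on MCF7 cells (Homo sapiens) for inhibition, read by sulforhodamine B assay (on this read-out higher numbers stand for weaker inhibition and lower numbers for stronger inhibition), compound 1 `O=C1C(Nc2ccccc2)=CC(=O)c2c1nc1n2[C@H]2OC[C@@H](O)[C@H]2OC1` gives > 4000 nM as a limit of the assay and not as a number. Within the data shown here, compound 2 `COc1cccc(NC2=CC(=O)c3c(nc4n3[C@H]3OC[C@@H](O)[C@H]3OC4)C2=O)c1` gives 3830 nM in this assay and so holds the only actual number so far, which leaves no numerical ranking of it against another compound.

Compound 3 `O=C1C(NCc2ccccc2)=CC(=O)c2c1nc1n2[C@H]2OC[C@@H](O)[C@H]2OC1` has not yet been measured. It differs from compound 2 by benzyl in place of 3-methoxyphenyl on an amine nitrogen, while the shared core stays the same.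

Among the measured compounds shown here, only one measured step bears on this change. Methoxy in place of hydrogen on an aromatic carbon gives an at least 1.0-fold lower number from compound 1 to compound 2 (0.01 log units; that floor lies within the scatter) and stays within the scatter. That step did not exchange the whole group on the amine nitrogen, so its guidance is thin, and no step beyond the scatter is expected in either direction in this assay.

The estimated change is a 1.1-fold lower number from compound 2 to compound 3 (0.04 log units; within the scatter) at most a small one, and a reading at the assay limit remains possible.

Compound 3 is expected near 3500 nM with an estimated range from 1300 nM to 8000 nM in this assay.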

Compound 3, half-maximal inhibitory concentration: > 8000 nM
Compound 3 ended at the assay's limit (the forecaster's own chance of this, stated with the estimate: 45%); middle value at least 2.2-fold (0.35 log units) from the limit.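

In this assay, benzyl in place of 3-methoxyphenyl on the amine nitrogen gives an at least 2.0-fold higher number from compound 2 to compound 3 (0.31 log units; beyond the scatter), and this is the only readable step shown that lies beyond the scatter. The group on this nitrogen, whose other neighbour is a double-bonded ring carbon, can therefore move the number in a way that the methoxy exchange on the aromatic ring did not, since that change gave an at least 1.0-fold lower number from compound 1 to compound 2 (0.01 log units; that floor lies within the scatter). The full size of the new step is unknown, as compound 3 is recorded only as a limit of the assay and not as a number: the limit of > 8000 nM in this assay, at which 1 of the 3 values shown sits.

The step from compound 1 to compound 3 cannot be read, as both values are limits, which leaves open whether benzyl and phenyl differ on this nitrogen. Also open, from the compounds shown here alone, is what a longer chain such as phenethyl, or a cyclohexyl group, would give on this nitrogen, and whether any group there can bring the number clearly under that of compound 2, which stands at 3830 nM.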